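This account rests on a few compounds, and the source may have more. Where it says the series, first, only, none or still open, it means among the compounds named here.

Compound 2 `COc1cc(N(C)CCN(C)C)c(NC(=O)/C=C\C(C)C)cc1Nc1nc(C)cc(-c2cn(C)c3ccc(F)cc23)n1` gives 8520 nM in a functional assay on NCI-H1975 cells (Homo sapiens) for antiproliferative activity, read by MTT assay, with a stated time of 72 h (a lower number here means a stronger inhibitor, a higher number a weaker inhibitor), the higher of the two numbers recorded so far. Compound 1 `CCC/C=C\C(=O)Nc1cc(Nc2nccc(-c3cn(C)c4ccc(F)cc34)n2)c(OC)cc1N(C)CCN(C)C`, which carries a different substitution on the shared core as well as a different chain on the amide, gives 2730 nM in this assay; the two values lie apart beyond the usual scatter, though compound 1 and compound 2 differ in more than one place, so the two numbers alone do not say which difference carries the gap.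

Compound 3 `CCC/C=C\C(=O)Nc1cc(Nc2nc(C)cc(-c3cn(C)c4ccc(F)cc34)n2)c(OC)cc1N(C)CCN(C)C` is the unmeasured partner of compound 2 and differs from it in a single place: propyl in place of isopropyl on a double-bonded chain carbon bound to a double-bonded chain carbon. The chain of compound 3 is thus the same as that in compound 1, while the core remains that of compound 2.

For the measured compounds named here, no measured pair shows this change by itself. Since compound 1, which bears the propyl chain, gives 2730 nM, compound 3 is expected to fall somewhat below compound 2, and the step from compound 2 to compound 3 is estimated at a 1.7-fold lower number from compound 2 to compound 3 (0.23 log units; within the scatter), a modest move towards stronger inhibition that may not clear the scatter. Compound 3 is therefore estimated at 5000 nM in this assay, within a range of 2000 nM to 12000 nM.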

Compound 3, half-maximal inhibitory concentration: 12200 nM
Estimate against measurement, compound 3: 2.4-fold (0.39 log units) below; measured number outside the range, above it.
By their numbers in this assay, from the lowest: compound 1; then compounds 2 and 3 (each within the scatter of the next).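

In this assay, propyl in place of isopropyl on a double-bonded chain carbon bound to a double-bonded chain carbon gives a 1.4-fold higher number from compound 2 to compound 3 (0.16 log units; within the scatter), so on this core the two chains cannot be told apart, although they are joined differently from the same atoms. The other step gives the first reading of a single change on the core: with the propyl chain held constant, methyl in place of hydrogen on an aromatic carbon gives a 4.5-fold higher number from compound 1 to compound 3 (0.65 log units; beyond the scatter), a weakening that stands beyond the scatter and is the only clear single-place effect among these compounds. No measurement shown here accounts for either step.

The compounds shown leave open whether propyl and isopropyl also read alike on the core of compound 1, and whether the methyl carries the same cost when the chain is isopropyl. They also leave open how a longer chain, or a chain ending in an amine, would read in this place, and how ethyl or methoxy would read in the place of the methyl.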